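A few compounds are considered here, and "the series" means these few. Any claim that something is new, unique, unknown or untested is made for them only; others in the source may bear on it.

Measured compounds:
compound 1 `C=C(Cl)C(=O)Nc1cc(Nc2nccc(-c3cn(C)c4ccccc34)n2)c(OC)cc1N(C)CCN(C)C` — 1390 nM
compound 2 `COc1cc(N(C)CCN(C)C)c(NC(=O)/C=C\C(C)C)cc1Nc1nccc(-c2cn(C)c3ccccc23)n1` — 4390 nM

Both compounds share the same core and differ only in the group on the amide carbonyl. In a functional assay on HepG2 cells (Homo sapiens) for antiproliferative activity, read by MTT assay, with a stated time of 72 h (on this read-out higher numbers stand for weaker inhibition and lower numbers for stronger inhibition), compound 1 gives 1390 nM, while compound 2 gives 4390 nM. Among the compounds with values here, the one step in hand, a 3.2-fold higher number from compound 1 to compound 2 (0.50 log units; beyond the scatter), puts compound 2 at the higher of the two numbers, beyond the scatter from compound 1.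

Compound 3 `CC/C=C\C(=O)Nc1cc(Nc2nccc(-c3cn(C)c4ccccc34)n2)c(OC)cc1N(C)CCN(C)C` has not been measured. It differs from compound 2 by hydrogen in place of methyl on a saturated chain carbon bound to a double-bonded chain carbon and a saturated chain carbon; read one bond further out, isopropyl becomes ethyl on the but-1-en-1-yl chain. Within the data shown here, no measured step bears on this change: the single step from compound 1 to compound 2 exchanges the whole acyl group rather than trimming a methyl from its chain. There is therefore no basis for a move in either direction beyond the scatter in this assay, and the working assumption is that compound 3 stays close to compound 2. Compound 3 is expected to give 3500 nM, with a range of 1400 nM to 9000 nM. The expected step is accordingly a 1.3-fold lower number from compound 2 to compound 3 (0.10 log units; within the scatter).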

Compound 3, half-maximal inhibitory concentration: 6670 nM
Estimate against measurement, compound 3: 1.9-fold (0.28 log units) below; the measured number falls inside the stated range.
By their numbers in this assay, from the lowest: compound 1; then compounds 2 and 3 (each within the scatter of the next).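

In this assay, going from isopropyl to ethyl on the but-1-en-1-yl chain gives a 1.5-fold higher number from compound 2 to compound 3 (0.18 log units; within the scatter), so removing this methyl from the saturated chain carbon has no readable effect on the number. The acyl exchange now has a second reading, a 4.8-fold higher number from compound 1 to compound 3 (0.68 log units; beyond the scatter), and it points the same way as a 3.2-fold higher number from compound 1 to compound 2 (0.50 log units; beyond the scatter): among these three compounds, compound 1, with 1-chloroethenyl on the carbonyl carbon, has the lowest number, and both other acyl groups lie beyond the scatter from it. The data on hand offer no measurement that explains this separation or the lack of a readable change at the chain position.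

The compounds shown leave open whether a longer chain, or an amine such as dimethylamino, at the end of the but-1-en-1-yl chain would shift the number beyond the scatter in this assay. They also leave open whether the lower number of compound 1 goes with its chlorine, a question that a plain ethenyl or a 1-bromoethenyl group on the carbonyl carbon would address.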